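Replacing a Thiophene Methyl Ether with a Phenyl Ether

This account rests on a few compounds, and the source may have more. Where it says the series, first, only, none or still open, it means among the compounds named here.

Three compounds share one core and differ only in the group carried on the oxygen on the aromatic ring. In a functional assay on the whole organism with Canis familiaris (Canis lupus familiaris) as the target, at a dose of 2 mg/kg by the intravenous route (on this read-out lower numbers stand for a weaker effect and higher numbers for a stronger effect at the one dose given), compound 1 `Cc1nc2c(OCc3ccccc3)cccn2c1N` gives 97%. Compound 2 `Cc1nc2c(OCc3cccs3)cccn2c1N` gives 77%, and compound 3 `Cc1nc2c(OCc3ccsc3)cccn2c1N` gives 82%. Compound 3 thus stands second highest of the three numbers: its gap to compound 2 lies within the scatter, whereas a number 15 percentage points lower from compound 1 to compound 3 (beyond the scatter) lies beyond it, as does a number 20 percentage points lower from compound 1 to compound 2 (beyond the scatter).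

Compound 4 `Cc1nc2c(Oc3ccccc3)cccn2c1N` has not yet been measured. Its difference from compound 3 is phenyl in place of (thiophen-3-yl)methyl on an oxygen on an aromatic ring. Two things change at once: the five-membered aromatic ring with one hetero atom gives way to a six-membered ring of carbon only, and the saturated chain carbon bound to the oxygen disappears. Only the ring change has a precedent, since a number 15 percentage points lower from compound 1 to compound 3 (beyond the scatter) shows a modest loss when thiophen-3-yl replaced phenyl, so undoing that replacement may recover a similar amount. Going by the values given here, for the loss of the chain carbon no measured step exists. Compound 4 is therefore expected to give 85%, within 55% to 98%. The expected step is a number 3 percentage points higher from compound 3 to compound 4 (within the scatter), with wide uncertainty.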

Compound 4, a percentage reported as inhibition, in the whole organism at one dose (the size of the read-out at that dose, not a potency): 40%
The estimate for compound 4 lay 45 percentage points above the measured number, and the stated range ends above it.
By their numbers in this assay, from the lowest: compound 4; then compounds 2 and 3 (each within the scatter of the next); then compound 1.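

In this assay, phenyl directly on the oxygen on an aromatic ring gives a number 42 percentage points lower from compound 3 to compound 4 (beyond the scatter) and a number 37 percentage points lower from compound 2 to compound 4 (beyond the scatter) as large steps, whereas exchanging the rings on the saturated chain carbon had produced only modest steps or one within the scatter. Compound 1, which carries the same phenyl on that chain carbon, gives 97% in this assay while compound 4, which lacks the chain carbon, gives 40% and so points to the chain carbon, more than the identity of the ring, as what matters at this position. Nothing available here accounts for the size of this loss.

The compounds shown leave open whether a longer chain on the oxygen would keep or lose the effect. They also do not show how a pyridine ring on the saturated chain carbon would compare with phenyl or the thiophenes.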